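Taking the methyl group off compound 3

The source may hold more compounds than are shown below. What is called first, only, known or untested is meant among the compounds shown, and "the series" means these compounds.

Measured in a functional assay on MGC-803 cells (Homo sapiens) for inhibition, read by MTT assay, with a stated time of 48 h; on this read-out lower numbers stand for stronger inhibition and higher numbers for weaker inhibition:
Compound 1 `COc1cc(NCc2ccccc2)cc(OC)c1OC` gives > 80000 nM (a limit)
Compound 2 `COc1ccc(CNc2cc(OC)c(OC)c(OC)c2)cc1Br` gives 29400 nM
Compound 3 `COc1ccc(CNc2cc(OC)c(OC)c(OC)c2)cc1C` gives 56800 nM

Compound 3 has the highest of the two actual numbers, yet its 56800 nM lies within the scatter of compound 2 at 29400 nM. The reading for compound 1 is a limit of the assay. Compound 4 `COc1ccc(CNc2cc(OC)c(OC)c(OC)c2)cc1` follows from compound 3 by one change, (hydrogen in place of methyl on an aromatic carbon), hydrogen in place of methyl on an aromatic carbon. For the measured compounds named here, one measured step bears on this place, a 1.9-fold higher number from compound 2 to compound 3 (0.29 log units; within the scatter), where methyl replaced bromo. Since that step stayed within the scatter, no large shift is expected in this assay. The expected step is a 1.1-fold higher number from compound 3 to compound 4 (0.02 log units; within the scatter), which would lie within the scatter. For compound 4 the estimated value is 60000 nM, with an expected range from 25000 nM to 130000 nM.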

Compound 4, half-maximal inhibitory concentration: 11400 nM
Compound 4: the middle estimate sits 5.3-fold (0.72 log units) above what was measured; the whole stated range lies above it.
By their numbers in this assay, from the lowest: compound 4; then compounds 2 and 3 (each within the scatter of the next). At a limit, above all of these: compound 1.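

Hydrogen at this position, ortho to a methoxy group, gives the lowest number of the series in this assay, so the position is not as indifferent as the earlier pair suggested. Both groups tried there give higher numbers than hydrogen, as shown by a 5.0-fold lower number from compound 3 to compound 4 (0.70 log units; beyond the scatter) and a 2.6-fold lower number from compound 2 to compound 4 (0.41 log units; beyond the scatter). The methoxy group also counts, with an at least 7.0-fold lower number from compound 1 to compound 4 (0.84 log units; beyond the scatter), though this step rests on a reading for compound 1 that is only a limit: the limit of > 80000 nM in this assay, at which 1 of the 4 values shown sits.

On these data alone, it remains open whether a fluoro, hydroxy or amino group at this position would also give a higher number than hydrogen.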